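The source may hold more compounds than are shown below. What is called first, only, known or untested is meant among the compounds shown, and "the series" means these compounds.

Of the compounds shown here, three built on one shared core have been measured in an assay on microsomes from brain for inhibition of Fatty-acid amide hydrolase 1 (Rattus norvegicus), read by fluorescence and HPLC, with a stated time of 60 min; on this read-out lower numbers stand for stronger inhibition and higher numbers for weaker inhibition. For the measured compounds named here, compound 1 `CC(Oc1ccc(Oc2ccc(F)cc2)cc1)C(=O)Cn1nnc(-c2ccc(Cl)cc2)n1` gives 42 nM, compound 2 `COC(=O)c1ccc(-c2nnn(CC(=O)C(C)Oc3ccc(Oc4ccc(F)cc4)cc3)n2)cc1` gives 36 nM, and compound 3 `CCCCCCCCc1ccc(OC(C)C(=O)Cn2nnc(-c3ccc(C(=O)O)cc3)n2)cc1` gives 50 nM; compound 3 lies within the scatter of both neighbours, and the only single-point step, a 1.2-fold lower number from compound 1 to compound 2 (0.07 log units; within the scatter), is likewise within the scatter. Compound 4 `CC(Oc1ccc(Oc2ccc(F)cc2)cc1)C(=O)Cn1nnc(-c2ccc(C(=O)O)cc2)n1` differs from compound 3 by 4-fluorophenoxy in place of octyl on an aromatic carbon. Going by the values given here, no measured pair swaps these two groups directly; compound 1 and compound 2 merely show that cores carrying the 4-fluorophenoxy group reach the same range as compound 3. One therefore expects no step beyond the scatter, a 1.3-fold lower number from compound 3 to compound 4 (0.10 log units; within the scatter). Compound 4 is estimated at 40 nM, with a range from 15 nM to 110 nM.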

Compound 4, half-maximal inhibitory concentration: 100 nM
Beside the measured number, compound 4's estimate is 2.5-fold (0.40 log units) below it, within the range that was stated.
By their numbers in this assay, from the lowest: compounds 2, 1, 3 and 4 (each within the scatter of the next, the first and the last beyond it).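

In this assay the exchange of octyl for 4-fluorophenoxy, with carboxy held in place, gives a step that stays within the scatter (a 2.0-fold higher number from compound 3 to compound 4 (0.30 log units; within the scatter)). With 4-fluorophenoxy held in place, the group on the other aromatic ring now gives modest steps, both for the free acid against its methyl ester (a 2.8-fold higher number from compound 2 to compound 4 (0.44 log units; beyond the scatter)) and for carboxy in place of chloro (a 2.4-fold higher number from compound 1 to compound 4 (0.38 log units; beyond the scatter)). No measurement shown here offers an explanation for these steps. Still open, going by these compounds, is how an amine or a shorter alkyl chain would read in place of octyl, and how octyl would read alongside chloro or the methyl ester.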